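Oleyl chain carbonyl variants against fatty-acid amide hydrolase

A few compounds are considered here, and "the series" means these few. Any claim that something is new, unique, unknown or untested is made for them only; others in the source may bear on it.

Working notes on the series. The reference ketone compound 1 `CCCCCCCCCCCCCC(=O)C(F)(F)F` gives 490 nM in an assay on isolated protein for inhibition of Fatty-acid amide hydrolase 1 (Homo sapiens); a lower number here means a stronger inhibitor, a higher number a weaker inhibitor. Compound 2 `CCCCCCCC/C=C\CCCCCCCC(OC)OC` is the dimethyl acetal of the oleyl series; in this assay compound 2 yields only a limit, > 300000 nM, and no number. Compound 3 `CCCCCCCC/C=C\CCCCCCC(=O)c1nc2cc(C)ccc2o1`, a ketone bearing a benzoxazole, likewise shows only a limit in this assay, > 100000 nM. Compound 2 therefore stands at the limit of > 300000 nM in this assay, at which 1 of the 3 values shown sits, while the other limit shown, (the limit of > 100000 nM in this assay, at which 1 of the 3 values shown sits), belongs to compound 3; the single numerical value in the set is that of compound 1.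

Compound 4 `CCCCCCCC/C=C\CCCCCCC(=O)c1nccn1C` is not yet measured. It differs from compound 2 by (1-methyl-1H-imidazol-2-yl)carbonyl in place of 2,2-dimethoxyethyl on a saturated chain carbon, six bonds along the chain from a double-bonded chain carbon. Among the measured compounds shown here, no measured step between neighbours exists here, so the size of the step to compound 4 is open; since compound 2 sits at a limit, any numerical result for compound 4 would mean a step toward stronger inhibition that lies beyond the scatter. Compound 4 is expected to land near 5000 nM, within 400 nM to 100000 nM, which is the estimated step of an at least 60-fold lower number from compound 2 to compound 4 (1.77 log units; beyond the scatter).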

Compound 4, inhibition constant: > 100000 nM
Compound 4 gave a limit, no number; the forecaster's own chance of this, stated with the estimate: 30%; at least 20-fold (1.30 log units) between middle value and limit.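

Compound 2 and compound 4 both show only limits in this assay, and the step between them cannot be read. The compounds shown leave open how strongly compound 2, compound 3 and compound 4 actually inhibit; none of the three gives a number in this assay.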